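Compound 3 to compound 4: replacing the 3-chlorophenyl group

The source may report more compounds than this note shows. Statements on the series, on what has been measured and on what is new or still open speak of the compounds shown alone.

In an ADME assay on L6 cells (Rattus norvegicus) for cytotoxicity, read by resazurin assay, with a stated time of 70 h (on this read-out lower numbers stand for stronger inhibition and higher numbers for weaker inhibition), compound 1 (`COc1cc(NC(C)CCCNC(=O)Nc2cccc(O)c2)c2ncccc2c1`) stands at (38 ug/mL), compound 2 (`COc1cc(NC(C)CCCNC(=O)Nc2cccc(F)c2)c2ncccc2c1`) at (9.18 ug/mL) and compound 3 (`COc1cc(NC(C)CCCNC(=O)Nc2cccc(Cl)c2)c2ncccc2c1`) at (10 ug/mL). Compound 3 thus has one close neighbour (a 1.1-fold higher number from compound 2 to compound 3 (0.04 log units; within the scatter)) and one distant one (a 3.8-fold lower number from compound 1 to compound 3 (0.58 log units; beyond the scatter)).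

Compound 4 (`COc1cc(NC(C)CCCNC(=O)NNC(=O)N(CCO)CCO)c2ncccc2c1`) differs from compound 3 by a single exchange ((bis(2-hydroxyethyl)carbamoyl)amino in place of 3-chlorophenyl on an amide-type nitrogen). Among the measured compounds shown here, no measured step covers an exchange of this kind, so only indirect evidence is available. The closest evidence is the pair of modest steps away from the hydroxy compound, the second being (a 4.1-fold lower number from compound 1 to compound 2 (0.62 log units; beyond the scatter)) alongside the one already given. The swap between the two halogens shows nothing beyond the scatter. In this small set the hydroxy-bearing compound 1 (38 ug/mL) carries the highest number, so a modest to larger step upward is expected in this assay, with low confidence.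

The expected change is (a 5.0-fold higher number from compound 3 to compound 4 (0.70 log units; beyond the scatter)). For compound 4 the estimated value is (50 ug/mL), with an expected range from (15 ug/mL) to (130 ug/mL).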

Compound 4, half-maximal inhibitory concentration: 79.9 ug/mL
The estimate for compound 4 lay 1.6-fold (0.20 log units) below the measured number; low and high end bracket the measured number.
By their numbers in this assay, from the lowest: compounds 2 and 3 (each within the scatter of the next); then compound 1; then compound 4.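

In this assay, among the compounds shown here, the first exchange at this amide-type nitrogen that removes the aromatic ring raises the number well beyond the scatter, with an 8.0-fold higher number from compound 3 to compound 4 (0.90 log units; beyond the scatter) and an 8.7-fold higher number from compound 2 to compound 4 (0.94 log units; beyond the scatter). The number still rises against the hydroxy-bearing phenyl compound, with a 2.1-fold higher number from compound 1 to compound 4 (0.32 log units; beyond the scatter), so both hydroxy-bearing compounds now stand above the two halogen compounds and compound 4 has the highest number of the four. No measurement shown accounts for this rise.

This single exchange removes the ring and brings in the hydroxyethyl chains together, and the compounds shown do not separate these two changes. As far as these compounds go, a diethylcarbamoylamino group would test the role of the hydroxy groups, while an amine or a carboxylic acid on the phenyl ring remains open at this position.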